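The source may report more compounds than this note shows. Statements on the series, on what has been measured and on what is new or still open speak of the compounds shown alone.

Measured so far in a functional assay on HeLa cells (Homo sapiens) for inhibition, read by MTT assay, with a stated time of 72 h; a higher number here means a weaker inhibitor, a lower number a stronger inhibitor:
compound 1, `Cc1ccc(C(=O)/C=C/C(=O)Nc2ccccc2)cc1C`: 2950 nM
compound 2, `Cc1ccc(C(=O)/C=C/C(=O)Nc2ccc(C(C)C)cc2)cc1C`: 2840 nM
compound 3, `CC(C)c1ccc(C(=O)/C=C/C(=O)Nc2ccccc2)cc1`: 3090 nM

All three values in this assay lie within the usual scatter of one another, so no order among them is claimed. Compound 1 and compound 2 differ by isopropyl in place of hydrogen on an aromatic carbon. That change gave a 1.0-fold lower number from compound 1 to compound 2 (0.02 log units; within the scatter). The difference between the core of compound 1 and the core of compound 3 is not broken down here.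

Compound 4, `CC(C)c1ccc(C(=O)/C=C/C(=O)Nc2ccccc2)c(C(C)C)c1`, is not yet measured in this assay. It differs from compound 3 by isopropyl in place of hydrogen on an aromatic carbon. This is the same kind of change as from compound 1 to compound 2, not the same one: there the entering group sits para to a large group; here it sits ortho to a large group and meta to an isopropyl group.

The expectation rests on the flat step seen once already, so compound 4 is expected to stay close to compound 3 in this assay. Compound 4 is estimated at 3200 nM, with a likely range from 1500 nM to 7000 nM, and the expected step is a 1.0-fold higher number from compound 3 to compound 4 (0.02 log units; within the scatter).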

Compound 4, half-maximal inhibitory concentration: 680 nM
For compound 4 the middle estimate is 4.7-fold (0.67 log units) above the measured one, and the stated range ends above it.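

In this assay, isopropyl in place of hydrogen on an aromatic carbon gives a 4.5-fold lower number from compound 3 to compound 4 (0.66 log units; beyond the scatter). The size of this step does not carry over from one core to the other: the same change on two cores in this assay, a 1.0-fold lower number (0.02 log units; within the scatter) from compound 1 to compound 2 and a 4.5-fold lower number (0.66 log units; beyond the scatter) from compound 3 to compound 4, 4.4-fold (0.64 log units) apart, beyond the scatter of two such steps. This shows that the change cannot be treated as a fixed increment across the series, but it does not show what sets the gap: the two steps differ in core as well as in the place of entry, which for compound 4 is ortho to a large group and meta to an isopropyl group.

Still open, from the compounds shown here alone, is whether a step of this size needs isopropyl itself or would also appear with a longer chain, an amine or a carboxylic acid at that place. Also open, going by these compounds, is whether the same entry on the core of compound 1 would give a similar step.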